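Bromo for methoxy at the solubility limit

The source may hold more compounds than are shown below. What is called first, only, known or untested is meant among the compounds shown, and "the series" means these compounds.

In a physicochemical assay for solubility, read by HPLC, at pH 7.4 (on this read-out lower numbers stand for lower solubility and higher numbers for higher solubility), compound 1 (`Cc1[nH]c2ccccc2c(=O)c1Br`) gives > 20000 nM as a limit of the assay, not a number. Compound 2 (`COc1ccc2[nH]c(C)c(Br)c(=O)c2c1`) gives > 20000 nM as a limit too, so it has no number of its own. Compound 2 thus stands at the limit of > 20000 nM in this assay, at which 2 of the 2 values shown sit, and has no rank to be read.

Compound 3 (`Cc1[nH]c2ccc(Br)cc2c(=O)c1Br`) carries bromo in place of methoxy on an aromatic carbon of a six-membered aromatic ring of carbon only, on the shared core (bromo in place of methoxy on an aromatic carbon). Going by the values given here, one measured step bears on this, namely a step that the two limits leave unreadable from compound 1 to compound 2 at the same aromatic carbon, and its size cannot be read. Among the compounds with values here, with a step that the two limits leave unreadable from compound 1 to compound 2 as the only guide, no size carries over, so no step beyond the scatter is expected in this assay in either direction. The estimated at least 1.1-fold lower number from compound 2 to compound 3 (0.04 log units; that floor lies within the scatter) carries this expectation, and the reading may again end in a limit. Compound 3 is estimated at 18000 nM with an expected range from 6000 nM to 35000 nM in this read-out.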

Compound 3, solubility: > 20000 nM
Compound 3 gave a limit, no number; the forecaster's own chance of this, stated with the estimate: 60%; middle value at least 1.1-fold (0.04 log units) away from the limit.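

Compound 3 joins compound 1 and compound 2 at a single limit, not a number, in this assay, so no new step can be read among the three: the limit of > 20000 nM in this assay, at which 3 of the 3 values shown sit.

The compounds shown leave open how far each solubility lies past that limit, and whether hydrogen, methoxy or bromo on that aromatic carbon makes any difference in this assay.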